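A few compounds are considered here, and "the series" means these few. Any claim that something is new, unique, unknown or untested is made for them only; others in the source may bear on it.

Measured in a functional assay on the whole organism for positive allosteric modulation, with Mus musculus as the target; a lower number here means that less compound is needed, a higher number that more compound is needed for the effect:
Compound 1 `CCC(=O)N(c1ccc(Cl)c(Cl)c1)C1CCCC1O`: 0.4 mg/kg
Compound 2 `CCC(=O)N(c1ccc(OC)c(OC)c1)C1CCCC1N(C)C`: 9 mg/kg
Compound 3 `CCC(=O)N(c1ccccc1Cl)C1CCCC1N(C)C`: 6 mg/kg

Compound 1 has the lowest number of the three, and the gaps to compound 3 and compound 2 both lie beyond the scatter. Compound 4 `CCC(=O)N(c1ccc(Cl)c(Cl)c1)C1CCCC1N(CC)CC` keeps the core of compound 1 but carries diethylamino in place of hydroxy on a saturated ring carbon. No single-place comparison among the measured compounds isolates this change. Compound 3, at 6 mg/kg, and compound 2, at 9 mg/kg, carry dimethylamino instead of hydroxy, though they also differ from compound 1 elsewhere. A rise beyond the scatter is therefore expected, with the estimated step of a 7.5-fold higher number from compound 1 to compound 4 (0.88 log units; beyond the scatter). For compound 4 the expected value is 3 mg/kg, with an estimated range from 0.8 mg/kg to 12 mg/kg.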

Compound 4, dose for half-maximal effect: 0.1 mg/kg
Beside the measured number, compound 4's estimate is 30-fold (1.48 log units) above it, and the stated range ends above it.
By their numbers in this assay, from the lowest: compound 4; then compound 1; then compounds 3 and 2 (each within the scatter of the next).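

In this assay the change from hydroxy to diethylamino on a saturated ring carbon gives a 4.0-fold lower number from compound 1 to compound 4 (0.60 log units; beyond the scatter) and shows that this position tolerates the larger group. The hydrogen-bond donor of hydroxy is therefore not required here for a low number. No measurement available bears on why the number falls. On these data alone, whether the gain depends on the size of the amine stays open, and dimethylamino or pyrrolidine on the core of compound 1 would address that. Methoxy at the same carbon would test the loss of the donor without an amine.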